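From phenyl to 4-bromophenyl at compound 3

The source may hold more compounds than are shown below. What is called first, only, known or untested is meant among the compounds shown, and "the series" means these compounds.

In a functional assay on MCF7 cells (Homo sapiens) for antiproliferative activity, read by MTT assay, with a stated time of 48 h (on this read-out higher numbers stand for weaker inhibition and lower numbers for stronger inhibition), compound 3 (`COc1cc(C2=N/C(=C\c3cc(Br)cc(Br)c3OC(C)=O)C(=O)NN2c2ncc(-c3ccccc3)s2)cc(OC)c1OC`) gives 410 nM and holds the lowest number of the three measured compounds, with compound 2 (`COc1ccc(C2=N/C(=C\c3cc(Br)cc(Br)c3OC(C)=O)C(=O)NN2c2ncc(-c3ccc(Br)cc3)s2)cc1OC`) at 3280 nM and compound 1 (`CC(=O)Oc1c(Br)cc(Br)cc1/C=C1\N=C(c2ccccc2)N(c2ncc(-c3ccc(Br)cc3)s2)NC1=O`) highest at 9490 nM in the same test. Compound 4 (`COc1cc(C2=N/C(=C\c3cc(Br)cc(Br)c3OC(C)=O)C(=O)NN2c2ncc(-c3ccc(Br)cc3)s2)cc(OC)c1OC`) takes bromo in place of hydrogen on an aromatic carbon of compound 3, para to a large group, so that phenyl becomes 4-bromophenyl (bromo in place of hydrogen on an aromatic carbon). Within the data shown here, no measured step isolates this change. Among the measured compounds shown here, the one available step a 2.9-fold lower number from compound 1 to compound 2 (0.46 log units; beyond the scatter) is modest and beyond the scatter, but it concerns 3,4-dimethoxyphenyl in place of phenyl elsewhere in the molecule and bears only indirectly. Compound 2 already carries the 4-bromophenyl and reads 3280 nM against compound 3 at 410 nM as the only hint, so a higher number is expected. The expected move is a modest step of a 2.4-fold higher number from compound 3 to compound 4 (0.39 log units; beyond the scatter) in this assay with wide uncertainty. For compound 4 the estimated value is 1000 nM within an expected range of 250 nM to 4000 nM in this test.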

Compound 4, half-maximal inhibitory concentration: 3160 nM
Beside the measured number, compound 4's estimate is 3.2-fold (0.50 log units) below it; the range from low to high includes it.
By their numbers in this assay, from the lowest: compound 3; then compounds 4 and 2 (each within the scatter of the next); then compound 1.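

Bromo in place of hydrogen on an aromatic carbon, read on its own for the first time, gives a 7.7-fold higher number from compound 3 to compound 4 (0.89 log units; beyond the scatter) in this assay, so the low number of compound 3 goes with the plain phenyl at this place. With 4-bromophenyl held fixed, an added methoxy gives a 1.0-fold lower number from compound 2 to compound 4 (0.02 log units; within the scatter), while 3,4,5-trimethoxyphenyl in place of phenyl gives a 3.0-fold lower number from compound 1 to compound 4 (0.48 log units; beyond the scatter), so the added methoxy does not separate these two compounds, and both stand apart from compound 1. Nothing measured here accounts for these steps.

Going by these compounds, whether fluoro, chloro, methoxy or an amine at this place would read like hydrogen or like bromo stays open. Also open, on these data alone, is whether the bromo step would hold alongside the phenyl or 3,4-dimethoxyphenyl found in compound 1 and compound 2.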